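This account rests on a few compounds, and the source may have more. Where it says the series, first, only, none or still open, it means among the compounds named here.

Working notes on the series in a functional assay on PC-3 cells (Homo sapiens) for cytotoxicity, read by MTT assay, with a stated time of 72 h; a higher number here means a weaker inhibitor, a lower number a stronger inhibitor.

Compound 1 `Cc1ccc(-c2ccnc(C(=O)Nc3ccc(Oc4ccnc5[nH]ccc45)cc3)n2)cc1` gives 6140 nM in this assay. Compound 2 `O=C(Nc1ccc(Oc2ccnc3[nH]ccc23)cc1)c1nccc(-c2cccc(Cl)c2)n1` carries a 3-chlorophenyl where compound 1 carries a 4-methylphenyl. In this assay compound 2 gives 7800 nM; the step of a 1.3-fold higher number from compound 1 to compound 2 (0.10 log units; within the scatter) is within the scatter. Compound 3 `Cc1ccc(-c2ccnc(C(=O)Nc3ccc(Oc4ccnc5[nH]ccc45)c(F)c3)n2)cc1` is the fluoro analogue of compound 1. In this assay compound 3 gives 520 nM and is the strongest inhibitor of the three: the step of a 12-fold lower number from compound 1 to compound 3 (1.07 log units; beyond the scatter) is beyond the scatter, and the number for compound 2 lies further still above that of compound 3.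

Compound 4 `O=C(Nc1ccc(Oc2ccnc3[nH]ccc23)c(F)c1)c1nccc(-c2cccc(Cl)c2)n1` is not yet measured. It differs from compound 3 by 3-chlorophenyl in place of 4-methylphenyl on an aromatic carbon. The same exchange has been run once already, on the pair without fluoro, where it gave a 1.3-fold higher number from compound 1 to compound 2 (0.10 log units; within the scatter), within the scatter. On that single precedent the exchange on compound 3 is expected to produce no step beyond the scatter; the estimated step is a 1.3-fold higher number from compound 3 to compound 4 (0.10 log units; within the scatter), taken in the same direction as the measured pair. Compound 4 is therefore expected to give about 660 nM in this assay, with a range from 250 nM to 1700 nM that allows for the usual repeat scatter on both compound 3 and the new number.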

Compound 4, half-maximal inhibitory concentration: 1380 nM
Estimate against measurement, compound 4: 2.1-fold (0.32 log units) below; measured number inside the range.
By their numbers in this assay, from the lowest: compound 3; then compound 4; then compounds 1 and 2 (each within the scatter of the next).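

In this assay the exchange of 4-methylphenyl for 3-chlorophenyl on the fluoro core gives a 2.7-fold higher number from compound 3 to compound 4 (0.42 log units; beyond the scatter), so this position can show a step beyond the scatter, which the pair without fluoro did not. That does not make the exchange dependent on the core, as the two readings still agree with each other: the same change on two cores in this assay, a 1.3-fold higher number (0.10 log units; within the scatter) from compound 1 to compound 2 and a 2.7-fold higher number (0.42 log units; beyond the scatter) from compound 3 to compound 4, 2.1-fold (0.32 log units) apart, within the scatter of two such steps. The fluoro in place of hydrogen now also holds with 3-chlorophenyl at this position, with a 5.7-fold lower number from compound 2 to compound 4 (0.75 log units; beyond the scatter), and its size there agrees with that on the 4-methylphenyl pair: the same change on two cores in this assay, a 12-fold lower number (1.07 log units; beyond the scatter) from compound 1 to compound 3 and a 5.7-fold lower number (0.75 log units; beyond the scatter) from compound 2 to compound 4, 2.1-fold (0.32 log units) apart, within the scatter of two such steps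

The exchange alters both the substituent and its place on the phenyl ring, and the compounds shown do not separate these two contributions. They also leave open how the series in this assay would respond to an amine or a carboxylic acid on that phenyl ring, and whether the fluoro gain would persist with such groups.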